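Imidazole regioisomer of a salicylic acid anti-inflammatory series

The source may hold more compounds than are shown below. What is called first, only, known or untested is meant among the compounds shown, and "the series" means these compounds.

Measured compounds:
compound 1 `O=C(O)c1cc(-n2ccnc2)ccc1O`, in a functional assay on the whole organism for inhibition, with Rattus norvegicus as the target, read by paw edema (on this read-out lower numbers stand for an effect already at smaller amounts and higher numbers for an effect only at larger amounts of compound), compound 1 gives 75 mg/kg
compound 2 `O=C(O)c1cc(-c2ccncn2)ccc1O`, compound 2 reaches only a limit in this assay, > 200 mg/kg
compound 3 `CCCCOC(=O)Oc1ccc(-n2cccc2)cc1C(=O)O`, in this assay compound 3 gives 52 mg/kg

Compound 1 stands at the highest of the two numbers in this assay, yet its gap to compound 3 lies within the scatter. Compound 2 reached no number, only the limit (the limit of > 200 mg/kg in this assay, at which 1 of the 3 values shown sits). Going by the values given here, no pair here differs in a single place, so nothing measured tells how a change at this position acts.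

Compound 4 `O=C(O)c1cc(-c2ncc[nH]2)ccc1O` differs from compound 1 by 1H-imidazol-2-yl in place of 1H-imidazol-1-yl on an aromatic carbon. Given the limit of compound 2, a C-linked ring at this position has not shown a number; a modest weakening is expected for compound 4, with a risk of a limit, a 1.6-fold higher number from compound 1 to compound 4 (0.20 log units; within the scatter). Compound 4 is estimated at 120 mg/kg, between 50 mg/kg and 300 mg/kg.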

Compound 4, dose for half-maximal effect: 200 mg/kg
Estimate against measurement, compound 4: 1.7-fold (0.22 log units) below; the range from low to high includes it.
By their numbers in this assay, from the lowest: compounds 3 and 1 (each within the scatter of the next); then compound 4.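

Going by these compounds alone, this is the first readable step at this position: in this assay, 1H-imidazol-2-yl in place of 1H-imidazol-1-yl gives a 2.7-fold higher number from compound 1 to compound 4 (0.43 log units; beyond the scatter). With the same atoms on the shared core, how the ring is joined therefore changes the result. Compound 2, also carbon-linked at this position, gives a limit rather than a number: the limit of > 200 mg/kg in this assay, at which 1 of the 4 values shown sits.

This single step cannot separate the new point of attachment from the hydrogen-bond donor that enters with it. A 1-methyl-1H-imidazol-2-yl group, which keeps the carbon link with a methyl on the ring nitrogen, would bear on that question.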